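The source may report more compounds than this note shows. Statements on the series, on what has been measured and on what is new or still open speak of the compounds shown alone.

Series notes on a functional assay on DLD-1 cells (Homo sapiens) for antiproliferative activity, read by CellTiter-Glo, with a stated time of 72 h; on this read-out lower numbers stand for stronger inhibition and higher numbers for weaker inhibition.

Compound 1 `CC1CCN(C2CCN(S(=O)(=O)c3cccc(N)c3)CC2)CC1` carries a 3-aminophenyl on the sulfonyl sulfur, with the rest of the molecule unchanged across the set. In this assay, among the measured compounds shown here, compound 1 gives 3400 nM, the highest of the two numbers measured so far; its nearest neighbour is compound 2, and the step of a 1700-fold lower number from compound 1 to compound 2 (3.23 log units; beyond the scatter) is the only measured step in the set. Compound 2 `CC1CCN(C2CCN(S(=O)(=O)c3cccc(-c4ccc5ccccc5c4)c3)CC2)CC1` gives 2 nM in this assay.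

Compound 3 `CC1CCN(C2CCN(S(=O)(=O)c3ccc(Cl)nc3)CC2)CC1` has not been measured. It differs from compound 1 in one place: 6-chloropyridin-3-yl in place of 3-aminophenyl on a sulfonyl sulfur. For the measured compounds named here, the single measured step concerns a much larger aromatic group entering on the same sulfur, so it bears on the present change only loosely: it shows that this position tolerates replacement of the amino-bearing ring and can move the number greatly. Going by the values given here, the 6-chloropyridin-3-yl is of the same heavy-atom count as the group it replaces, so no step of that size is expected here; a modest move toward lower numbers, possibly within the scatter, is the expectation, with the step of a 2.3-fold lower number from compound 1 to compound 3 (0.36 log units; beyond the scatter) estimated for compound 3.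

Compound 3 is estimated in this assay at 1500 nM, with a range from 200 nM to 10000 nM.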

Compound 3, half-maximal inhibitory concentration: 3700 nM
Beside the measured number, compound 3's estimate is 2.5-fold (0.39 log units) below it, within the range that was stated.
By their numbers in this assay, from the lowest: compound 2; then compounds 1 and 3 (each within the scatter of the next).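

In this assay, among the compounds shown here, 6-chloropyridin-3-yl in place of 3-aminophenyl on the sulfonyl sulfur gives a 1.1-fold higher number from compound 1 to compound 3 (0.04 log units; within the scatter) and lies within the scatter, so this position now shows a change that leaves the read-out essentially unmoved, where the only earlier step was large. The entering group has the same heavy-atom count as the group it replaces but no hydrogen-bond donor, and the printed values put compound 3 far from compound 2 at 2 nM so that losing the amino group alone does not account for the large earlier step. The compounds shown offer no evidence on the reason for either outcome.

The range between these values remains unmapped at this position: a plain phenyl, a biphenyl or a quinoline on the sulfonyl sulfur would show how the number runs between the small aromatic groups and naphthalen-2-yl. Going by these compounds, it also remains open whether a carboxylic acid or a methoxy group on the naphthalen-2-yl of compound 2 would keep its low number.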